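Working notes: aryl variation on the amide-type nitrogen

The source may hold more compounds than are shown below. What is called first, only, known or untested is meant among the compounds shown, and "the series" means these compounds.

Measured so far:
compound 1 `Cc1cc(C)c(NC(=O)N(Cc2ccccc2)Cc2ccccc2)cc1C`, 0.16 ug/mL
compound 2 `O=C(Nc1cc(Cl)cc(Cl)c1)N(Cc1ccccc1)Cc1ccccc1`, 1.53 ug/mL
compound 3 `Cc1c(Cl)cccc1NC(=O)N(Cc1ccccc1)Cc1ccccc1`, 3.06 ug/mL

In an assay on isolated protein for inhibition of sterol O-acyltransferase 1 (Rattus norvegicus) (a lower number here means a stronger inhibitor, a higher number a weaker inhibitor), compound 3 carries the highest number of the three. Against compound 2 the gap is a 2.0-fold higher number from compound 2 to compound 3 (0.30 log units; within the scatter), so the two cannot be ordered; against compound 1 it is a 19-fold higher number from compound 1 to compound 3 (1.28 log units; beyond the scatter), and compound 1 to compound 2 gives a 9.6-fold higher number from compound 1 to compound 2 (0.98 log units; beyond the scatter).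

Compound 4 `Cc1ccc(NC(=O)N(Cc2ccccc2)Cc2ccccc2)cc1Cl` differs from compound 3 by 3-chloro-4-methylphenyl in place of 3-chloro-2-methylphenyl on an amide-type nitrogen. Going by the values given here, no measured step rearranges substituents within one ring; the only aryl-to-aryl step that keeps one chlorine, compound 2 to compound 3, lies within the scatter. For compound 4 no step beyond the scatter is expected, a 1.2-fold lower number from compound 3 to compound 4 (0.09 log units; within the scatter). Compound 4 is estimated at 2.5 ug/mL, range 0.8 ug/mL to 8 ug/mL.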

Compound 4, half-maximal inhibitory concentration: 6.88 ug/mL
Compound 4: middle estimate off by 2.8-fold (0.44 log units), on the low side; measured number inside the range.
By their numbers in this assay, from the lowest: compound 1; then compounds 2 and 3 (each within the scatter of the next); then compound 4.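

Swapping 3-chloro-2-methylphenyl for 3-chloro-4-methylphenyl keeps the same atoms on the amide-type nitrogen, yet in this assay the rearrangement alone gives a 2.2-fold higher number from compound 3 to compound 4 (0.35 log units; beyond the scatter), so the arrangement within the ring matters here and not only its atoms. Compound 4 now carries the highest number of the series, with a 4.5-fold higher number from compound 2 to compound 4 (0.65 log units; beyond the scatter) and a 43-fold higher number from compound 1 to compound 4 (1.63 log units; beyond the scatter). No measurement shown explains these steps.

Open, from the compounds shown here alone, is how this assay responds to a methoxy group, an amine or a carboxylic acid on this ring. Also open, going by these compounds, is whether the order of these aryl groups holds with anything other than the two benzyl groups on the urea's other nitrogen.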